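Swapping hydrogen for hydroxy on compound 2

A few compounds are considered here, and "the series" means these few. Any claim that something is new, unique, unknown or untested is made for them only; others in the source may bear on it.

In a functional assay on a cell-free system (Platelet, plasma, Oryctolagus cuniculus) for inhibition, with a stated time of 5 min, at 37 degrees C (a higher number here means a weaker inhibitor, a lower number a stronger inhibitor), compound 1 (`COc1cc(/C=C/C(=O)O)ccc1OC(=O)c1nc(C)c(C)nc1C`) gives 44600 nM and compound 2 (`Cc1nc(C)c(C(=O)Oc2ccc(/C=C/C(=O)O)cc2)nc1C`) gives 37800 nM so the two stand level within the usual scatter. Compound 3 (`Cc1nc(C)c(C(=O)Oc2ccc(/C=C/C(=O)O)cc2O)nc1C`) has hydroxy in place of hydrogen on an aromatic carbon of compound 2, ortho to a large group (hydroxy in place of hydrogen on an aromatic carbon). Among the measured compounds shown here, one measured step bears on this: a 1.2-fold lower number from compound 1 to compound 2 (0.07 log units; within the scatter) with hydrogen in place of methoxy on an aromatic carbon, and it stays within the scatter. A similarly small change is therefore expected, namely a 1.1-fold lower number from compound 2 to compound 3 (0.03 log units; within the scatter) in this assay with no shift beyond the scatter. Compound 3 is estimated to give 35000 nM within an expected range of 12000 nM to 90000 nM when measured.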

Compound 3, half-maximal inhibitory concentration: 84600 nM
Compound 3: the middle estimate sits 2.4-fold (0.38 log units) below what was measured; the measured number falls inside the stated range.
By their numbers in this assay, from the lowest: compounds 2, 1 and 3 (each within the scatter of the next, the first and the last beyond it).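

In this assay, hydroxy on this aromatic carbon brings a 2.2-fold higher number from compound 2 to compound 3 (0.35 log units; beyond the scatter), a modest step beyond the scatter, so this position does respond to some changes, which the swap between methoxy and hydrogen did not show. Hydroxy and methoxy stand level here, with a 1.9-fold higher number from compound 1 to compound 3 (0.28 log units; within the scatter), which lies within the scatter. Nothing here gives a measured reason for the weaker result with hydroxy. As far as these compounds go, whether an amine, a chlorine atom or a longer chain such as ethoxy on this carbon would move the number further remains open.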